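The source may report more compounds than this note shows. Statements on the series, on what has been measured and on what is new or still open speak of the compounds shown alone.

Compound 1, with the structure `CCCOC(=O)C1=C(C)N(C)C(=O)NC1c1ccco1`, was tested in an assay on membranes from HeLa cells for displacement of a labelled ligand from adenosine receptor A3 (Homo sapiens), read by scintillation counting, with a stated time of 180 min, tested at 1 uM (a lower number here means less inhibition, a higher number more inhibition at the concentration tested (going by the name of the read-out)), and gave 8%. Compound 2, with the structure `CCCOC(=O)C1=C(C)N(C)C(=O)NC1c1cccs1`, gave 4% in the same test, and compound 3, with the structure `CC1=C(C(=O)OCc2ccccc2)C(c2cccs2)NC(=O)N1C`, gave 18%. Among these three numbers compound 2 stands lowest, though one of the two steps that touch it is only a number 4 percentage points lower from compound 1 to compound 2 (within the scatter), while the other is a number 14 percentage points higher from compound 2 to compound 3 (beyond the scatter).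

Compound 4, with the structure `CCCOC(=O)C1=C(C)N(C)C(=O)NC1c1ccsc1`, has not yet been measured. It differs from compound 2 in one place: thiophen-3-yl in place of thiophen-2-yl on a saturated ring carbon. The measured step that bears on this change is the one on the same saturated ring carbon, where thiophen-2-yl replaced furan-2-yl and produced a number 4 percentage points lower from compound 1 to compound 2 (within the scatter). The other step, from compound 2 to compound 3, concerns the propoxycarbonyl side of the shared core, so it says nothing about the aromatic ring on the saturated ring carbon. Swapping one aromatic ring for another on that carbon left the reading essentially unchanged once, so a step of a number 2 percentage points higher from compound 2 to compound 4 (within the scatter) is expected here, which is to say none beyond the scatter. Compound 4 is therefore estimated to give 6% in this assay, within a range from -4% to 16%.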

Compound 4, a percentage reported as inhibition, at one concentration (the size of the read-out at that concentration, not a potency): 11%
Beside the measured number, compound 4's estimate is 5 percentage points below it, and the stated range covers the measured number.
By their numbers in this assay, from the lowest: compounds 2, 1, 4 and 3 (each within the scatter of the next, the first and the last beyond it).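

In this assay, moving the attachment point of the thiophene on the saturated ring carbon, with thiophen-3-yl in place of thiophen-2-yl, gives a number 7 percentage points higher from compound 2 to compound 4 (within the scatter), so this change of attachment point on the same ring does not separate the two compounds. Replacing the furan-2-yl group on that carbon gives a number 3 percentage points higher from compound 1 to compound 4 (within the scatter), which means that furan-2-yl, thiophen-2-yl and thiophen-3-yl, with the propoxycarbonyl group held constant, all lie within the scatter of one another at the single concentration tested. No accompanying measurement offers an explanation for these readings.

Every group on this carbon among these compounds is a five-membered aromatic ring with one hetero atom, so it remains open whether a plain phenyl, a phenyl carrying an amine, or a non-aromatic cyclohexyl group would move the number beyond the scatter. It is also open whether thiophen-3-yl would give a reading like that of thiophen-2-yl when paired with the phenyl-bearing ester of compound 3, and how any of these compounds would compare as a true potency rather than a reading at one concentration.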